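The source may hold more compounds than are shown below. What is called first, only, known or untested is meant among the compounds shown, and "the series" means these compounds.

The three measured compounds share one core and differ only on a nitrogen on an aromatic ring. Compound 1 `CCCCCCCCn1cc(/C=C/C(=O)c2ccc(NC(=O)CBr)cc2)nn1` gives 8460 nM in a functional assay on SK-N-SH cells (Homo sapiens) for inhibition, read by MTT assay; a lower number here means a stronger inhibitor, a higher number a weaker inhibitor. Compound 2 `CCCCCCCCn1cc(/C=C/C(=O)c2ccc(N)cc2)nn1` gives 28800 nM in this assay, and compound 3 `CCCCCCCCn1cc(/C=C/C(=O)c2ccc(NC(=O)CN3CCN(c4ccc([N+](=O)[O-])cc4)CC3)cc2)nn1` gives 51400 nM. Compound 2 stands second highest of the three numbers: compound 3 lies nearest, within the scatter, and compound 1 lies furthest, beyond the scatter. For the measured compounds named here, the single step between measured compounds, a 3.4-fold higher number from compound 1 to compound 2 (0.53 log units; beyond the scatter), is a modest one and concerns hydrogen in place of (bromomethyl)carbonyl on a nitrogen on an aromatic ring. Compound 4 `CCCCCCCCCCn1cc(/C=C/C(=O)c2ccc(N)cc2)nn1` has not yet been measured. It differs from compound 2 in another place: ethyl in place of hydrogen on a saturated chain carbon, eight bonds along the chain from an aromatic nitrogen. Going by the values given here, no measured step touches the saturated chain, so that one step does not bear on this change, and the data give no direction for it. Compound 4 is therefore expected to stay close to compound 2, and a 1.0-fold lower number from compound 2 to compound 4 (0.01 log units; within the scatter) is expected to fall within the scatter. Compound 4 is estimated to give 28000 nM in this assay, with a range from 11000 nM to 70000 nM.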

Compound 4, half-maximal inhibitory concentration: 83400 nM
For compound 4 the middle estimate is 3.0-fold (0.47 log units) below the measured one; the whole stated range lies below it.
By their numbers in this assay, from the lowest: compound 1; then compounds 2, 3 and 4 (each within the scatter of the next, the first and the last beyond it).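

In this assay, the saturated chain turns out not to be a silent place: ethyl in place of hydrogen on a saturated chain carbon, eight bonds along the chain from an aromatic nitrogen, gives a 2.9-fold higher number from compound 2 to compound 4 (0.46 log units; beyond the scatter), a modest step towards a weaker inhibitor. For the compounds shown here, this is the first measured step at this position, so the chain now has a direction where the earlier compounds offered none, and this step counts as modest just as a 3.4-fold higher number from compound 1 to compound 2 (0.53 log units; beyond the scatter) does, although the two changes lie in different places. Nothing measured here accounts for the loss.

This one step cannot show whether the number rises steadily with chain size or whether a shorter chain such as butyl, or a longer one such as dodecyl, would break the trend. It also leaves open whether the same ethyl change would carry over to the core of compound 1, with (bromomethyl)carbonyl on the nitrogen, and how a chain ending in an amine or a carboxylic acid would read.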